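Swapping Methyl for Fluoro on an Aromatic Carbon

The source may hold more compounds than are shown below. What is called first, only, known or untested is meant among the compounds shown, and "the series" means these compounds.

Of the compounds shown here, two with a shared core have been measured so far. Compound 1 `O=S(=O)(Nc1ccncc1Nc1cccc(Br)c1)C(F)(F)F` in a functional assay on the whole organism (strain Wistar) with Rattus norvegicus as the target, with stated times of 30 min and 4 h, at a dose of 10 mg/kg by the intraperitoneal route (on this read-out lower numbers stand for a weaker effect and higher numbers for a stronger effect at the one dose given), gives 27.1%. Compound 2 `Cc1ccc(Nc2cnccc2NS(=O)(=O)C(F)(F)F)cc1Br` carries a methyl in place of hydrogen on an aromatic carbon, and in this assay compound 2 gives 26.2%. Within the data shown here, the one measured step is a number 0.9 percentage points lower from compound 1 to compound 2 (within the scatter), so the two numbers cannot be told apart. Among the measured compounds shown here, compound 2 therefore stands together with compound 1, the only other compound measured, with nothing to set it above or below.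

Compound 3 `O=S(=O)(Nc1ccncc1Nc1ccc(F)c(Br)c1)C(F)(F)F` is not yet measured. Its change from compound 2 is fluoro in place of methyl on an aromatic carbon. For the measured compounds named here, only one measured step touches that same aromatic carbon, the step from hydrogen to methyl, and it stayed within the scatter. A single step on one position is thin ground, and a fluoro has not been tried here at all. No step beyond the scatter is expected, in either direction. The expected step is a number 0.2 percentage points lower from compound 2 to compound 3 (within the scatter), and compound 3 is estimated at 26%, within a range from 15% to 37%.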

Compound 3, a percentage reported as activity, at one dose (the size of the read-out at that dose, not a potency): 41.2%
Compound 3: middle estimate off by 15.2 percentage points, on the low side; measured number outside the range, above it.
By their numbers in this assay, from the lowest: compounds 2 and 1 (each within the scatter of the next); then compound 3.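

This aromatic carbon turns out not to be indifferent to what it carries: in this assay fluoro in place of methyl gives a number 15 percentage points higher from compound 2 to compound 3 (beyond the scatter) and fluoro in place of hydrogen gives a number 14.1 percentage points higher from compound 1 to compound 3 (beyond the scatter) on the same read-out. The earlier pair could not be told apart, so a change at this carbon had shown nothing until now; fluoro is the first group here to separate from both hydrogen and methyl, and compound 3 has the highest number of the three. Nothing available explains why fluoro behaves differently from methyl on this carbon, so the result stands as an observation without a cause.

On these data alone, it remains open whether the gain belongs to fluoro alone or would also appear with another group on the same carbon, such as chloro, methoxy or an amine, and whether it would survive if the bromo group were replaced. The read-out also reports the size of the effect at a single dose, so these numbers say nothing about potency, and a dose series would be needed to address that.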